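Swapping the aryl group of compound 2 for a morpholine amide

The compounds below may be only part of what the source reports. "The series", "measured", "known", "first", "only" and "open" are said of these compounds alone.

Three compounds with a shared core carrying a seven-carbon chain ending in a phenyl ring have been measured in an assay (Rattus norvegicus) for inhibition of Fatty-acid amide hydrolase 1 (Homo sapiens); a higher number here means a weaker inhibitor, a lower number a stronger inhibitor. Compound 1 `COC(=O)c1ccccc1-c1cnc(C(=O)CCCCCCc2ccccc2)o1` gives 60 nM. Compound 2 `Cc1ccnc(-c2cnc(C(=O)CCCCCCc3ccccc3)o2)c1` gives 0.6 nM, the lowest of the three numbers, with compound 3 nearest at a step of a 5.8-fold higher number from compound 2 to compound 3 (0.77 log units; beyond the scatter) and compound 1 furthest, as the two values shown make plain. Compound 3 `O=C(CCCCCCc1ccccc1)c1ncc(-c2cc(C(F)(F)F)ccn2)o1` gives 3.5 nM.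

The next compound, compound 4 `O=C(CCCCCCc1ccccc1)c1ncc(C(=O)N2CCOCC2)o1`, differs from compound 2 in one place: (morpholin-4-yl)carbonyl in place of 4-methylpyridin-2-yl on an aromatic carbon. Within the data shown here, the only measured step that bears on this position is the one from compound 2 to compound 3, where a modest loss of a 5.8-fold higher number from compound 2 to compound 3 (0.77 log units; beyond the scatter) followed a small change within the same aromatic ring. Compound 1 shows that a different six-membered aromatic group at this position can cost far more, although its change from compound 2 is not a single step. Replacing the whole aromatic ring with a non-aromatic carbonyl-linked group is a larger alteration than either, so a sizeable weakening is expected. Compound 4 is estimated to give 150 nM in this assay, within 30 nM to 800 nM, a step of a 250-fold higher number from compound 2 to compound 4 (2.40 log units; beyond the scatter).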

Compound 4, inhibition constant: 24 nM
Compound 4: middle estimate off by 6.3-fold (0.80 log units), on the high side; the measured number lies below the stated range.
By their numbers in this assay, from the lowest: compound 2; then compound 3; then compound 4; then compound 1.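

In this assay, the step of a 40-fold higher number from compound 2 to compound 4 (1.60 log units; beyond the scatter) is the first one shown that replaces the whole group on the aromatic carbon next to the ring oxygen, and it is a large step, whereas the modest step of a 5.8-fold higher number from compound 2 to compound 3 (0.77 log units; beyond the scatter) changed only a substituent on the six-membered aromatic ring. It shows that this ring can be lost at this place with binding still measurable, as compound 4 gives 24 nM with a non-aromatic ring joined through a carbonyl, though at a clear cost against compound 2. The change alters the ring type, the hetero atoms and the link all at once, and nothing measured here separates their contributions or explains the loss.

The compounds shown leave open whether the ring oxygen of the morpholine matters, which a piperidine amide would address, and whether the carbonyl link matters, which a morpholine ring attached directly to the core would address. They also leave open how a carboxylic acid or a simple dimethyl amide would compare with compound 4 at this place.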